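The compounds below may be only part of what the source reports. "The series", "measured", "known", "first", "only" and "open" are said of these compounds alone.

Of the compounds shown here, three sharing one core have been tested in a functional assay (aorta) for antagonist activity, with Oryctolagus cuniculus as the target; on this read-out higher numbers stand for weaker inhibition and lower numbers for stronger inhibition. Compound 1 `CCCCc1ccc(CNCc2ccccc2)c(=O)n1Cc1ccc(-c2ccccc2-c2nn[nH]n2)cc1` gives 1 nM. Compound 2 `CCCCc1ccc(CNC(=O)Nc2ccccc2)c(=O)n1Cc1ccc(-c2ccccc2-c2nn[nH]n2)cc1` gives 30 nM, and compound 3 `CCCCc1ccc(CNC(=O)NC2CCCCC2)c(=O)n1Cc1ccc(-c2ccccc2-c2nn[nH]n2)cc1` gives 90 nM, the highest of the three numbers. The steps of a 30-fold higher number from compound 1 to compound 2 (1.48 log units; beyond the scatter) and a 90-fold higher number from compound 1 to compound 3 (1.95 log units; beyond the scatter) show that either carbamoyl group in place of benzyl costs a great deal, while a 3.0-fold higher number from compound 2 to compound 3 (0.48 log units; beyond the scatter) shows a modest further loss when cyclohexyl stands in for phenyl. Compound 4 `CCCCc1ccc(CNS(=O)(=O)c2ccccc2)c(=O)n1Cc1ccc(-c2ccccc2-c2nn[nH]n2)cc1` has not yet been measured; it differs from compound 3 in one place: phenylsulfonyl in place of cyclohexylcarbamoyl on an amine nitrogen. This change brings back a six-membered aromatic ring, as in compound 2, while the nitrogen stays non-basic, as in compounds 2 and 3. Because compound 2 gives 30 nM, the change is expected to come out as a 3.0-fold lower number from compound 3 to compound 4 (0.48 log units; beyond the scatter). Compound 4 is therefore estimated at 30 nM, with a range from 8 nM to 120 nM.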

Compound 4, half-maximal inhibitory concentration: 7 nM
The estimate for compound 4 lay 4.3-fold (0.63 log units) above the measured number; the measured number lies below the stated range.
By their numbers in this assay, from the lowest: compound 1; then compound 4; then compound 2; then compound 3.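

Compound 2 and compound 4 carry the same phenyl ring and differ only in the group joining it to the amine nitrogen, and a 4.3-fold lower number from compound 2 to compound 4 (0.63 log units; beyond the scatter) shows that this joining group matters as well as the ring. Phenylsulfonyl also compares well with cyclohexylcarbamoyl, with a 13-fold lower number from compound 3 to compound 4 (1.11 log units; beyond the scatter), yet it does not match benzyl, as a 7.0-fold higher number from compound 1 to compound 4 (0.85 log units; beyond the scatter) shows. The data shown offer no measurement that explains why phenylsulfonyl gives a lower number than either carbamoyl group.

The compounds shown leave open whether cyclohexyl in place of phenyl on the sulfonyl would raise the number, as it did on the carbamoyl. They also leave open how a methylsulfonyl group, or a chlorine or methoxy group on the phenyl ring of phenylsulfonyl, would compare.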